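Lengthening the Amide Chain from Octyl to Tetradecyl

A few compounds are considered here, and "the series" means these few. Any claim that something is new, unique, unknown or untested is made for them only; others in the source may bear on it.

Measured compounds:
compound 1, `CCCCCCCCNC(=O)[C@@H](NC(=O)c1ccccc1)[C@@H](C)O`, 200000 nM
compound 2, `CCCCCCCCNC(=O)[C@@H](NC(=O)c1cc2ccccc2o1)[C@@H](C)O`, 200000 nM
compound 3, `CCCCCCCCNC(=O)[C@@H](NC(=O)/C=C/c1ccccc1)[C@@H](C)O`, 61400 nM

The three measured compounds share one core and differ only in the group on the carbonyl carbon. In a functional assay on SW-620 cells (Homo sapiens) for cytotoxicity, read by MTT assay, with a stated time of 48 h (a higher number here means a weaker inhibitor, a lower number a stronger inhibitor), compound 1 gives 200000 nM, level with compound 2 at the digits shown, and the two together stand highest of the three numbers; compound 3 gives the lowest. Compound 4 `CCCCCCCCCCCCCCNC(=O)[C@@H](NC(=O)c1ccccc1)[C@@H](C)O` carries hexyl in place of hydrogen on a saturated chain carbon, eight bonds along the chain from an amide-type nitrogen. Among the compounds with values here, none of the measured steps touches this chain: no change at the digits printed from compound 1 to compound 2 (within the scatter), a 3.3-fold lower number from compound 1 to compound 3 (0.51 log units; beyond the scatter) and a 3.3-fold lower number from compound 2 to compound 3 (0.51 log units; beyond the scatter) all exchange the group on the carbonyl carbon. The data give no guide for the chain itself. For compound 4 the expected step is a 1.3-fold lower number from compound 1 to compound 4 (0.12 log units; within the scatter), nothing beyond the scatter. Compound 4 is estimated to give 150000 nM, within 40000 nM to 400000 nM.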

Compound 4, half-maximal inhibitory concentration: 200000 nM
Estimate against measurement, compound 4: 1.3-fold (0.12 log units) below, within the range that was stated.
By their numbers in this assay, from the lowest: compound 3; then compounds 1, 2 and 4 (each within the scatter of the next).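

Within the data shown here, compound 4 gives the first measured change to the amide chain itself: in this assay, hexyl in place of hydrogen, which turns octyl into tetradecyl, gives no change at the digits printed from compound 1 to compound 4 (within the scatter). With phenyl on the carbonyl carbon, this longer chain therefore leaves the number where it stood. Nothing measured here offers an explanation for this result.

On these data alone, whether tetradecyl would behave the same way with the 2-phenylethenyl group of compound 3 remains open. So does the outcome for a shorter chain, such as butyl, or for a chain carrying an amine.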